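Fluoro to methoxy on the benzyl ring of compound 3

This account rests on a few compounds, and the source may have more. Where it says the series, first, only, none or still open, it means among the compounds named here.

Three analogues share one core. In a functional assay on HCT-15 cells (Homo sapiens) for inhibition, read by sulforhodamine B assay, with a stated time of 48 h (a lower number here means a stronger inhibitor of growth, a higher number a weaker inhibitor of growth), compound 1 `Nc1cc(N)c2nc(-c3ccccc3)c(NCc3ccc(Cl)c(Cl)c3)nc2c1` gives 4680 nM; compound 2 `COc1ccc(CNc2nc3cc(N)cc(N)c3nc2-c2ccccc2)cc1OC` gives 30200 nM; compound 3 `Nc1cc(N)c2nc(-c3ccccc3)c(NCc3ccc(F)cc3)nc2c1` gives 3310 nM. Compound 3 holds the lowest of the three numbers, yet the step of a 1.4-fold lower number from compound 1 to compound 3 (0.15 log units; within the scatter) is within the scatter, while a 9.1-fold lower number from compound 2 to compound 3 (0.96 log units; beyond the scatter) is beyond it. Compound 4 `COc1ccc(CNc2nc3cc(N)cc(N)c3nc2-c2ccccc2)cc1` differs from compound 3 by methoxy in place of fluoro on an aromatic carbon. Among the measured compounds shown here, no measured step swaps exactly these two groups. The bearing steps are a 6.5-fold higher number from compound 1 to compound 2 (0.81 log units; beyond the scatter) and a 9.1-fold lower number from compound 2 to compound 3 (0.96 log units; beyond the scatter), in which methoxy on this ring went with a higher number both times. A single methoxy is a smaller change than two, so a modest step of a 2.4-fold higher number from compound 3 to compound 4 (0.38 log units; beyond the scatter) toward a higher number is expected. Compound 4 is estimated at 8000 nM, with a range from 3000 nM to 25000 nM.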

Compound 4, concentration for 50% growth inhibition: 15800 nM
The estimate for compound 4 lay 2.0-fold (0.30 log units) below the measured number; low and high end bracket the measured number.
By their numbers in this assay, from the lowest: compounds 3 and 1 (each within the scatter of the next); then compounds 4 and 2 (each within the scatter of the next).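

In this assay, a single methoxy in place of fluoro on this aromatic carbon is enough to shift the number, with a 4.8-fold higher number from compound 3 to compound 4 (0.68 log units; beyond the scatter). The second methoxy adds nothing readable, with a 1.9-fold lower number from compound 2 to compound 4 (0.28 log units; within the scatter). The 4-methoxyphenyl group also stands apart from 3,4-dichlorophenyl, with a 3.4-fold higher number from compound 1 to compound 4 (0.53 log units; beyond the scatter), so within these compounds the methoxy-bearing rings group together and the halogen-bearing rings group together.

Nothing here gives a reason for this split. On these data alone, whether an amine or a hydroxy group on this carbon would fall with fluoro or with methoxy remains open.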